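This account rests on a few compounds, and the source may have more. Where it says the series, first, only, none or still open, it means among the compounds named here.

Measured compounds:
compound 1 `CCCCc1nc(C(C)C)c(CC(=O)OC)c(=O)n1Cc1ccc(-c2ccccc2-c2noc(=O)[nH]2)cc1` gives 9.4% in an ADME assay on microsomes from liver (Mus musculus) for metabolic stability, with a stated time of 30 min; a higher number here means that more of the compound is left, a lower number that less of the compound is left
compound 2 `CCCCOC(=O)Cc1c(C(C)C)nc(CCCC)n(Cc2ccc(-c3ccccc3-c3noc(=O)[nH]3)cc2)c1=O` gives 21.6% in this assay

Compound 1 stands lowest of the two numbers in this assay. Compound 3 `CCCCc1nc(C(C)C)c(CC(=O)OC2CCCCC2)c(=O)n1Cc1ccc(-c2ccccc2-c2noc(=O)[nH]2)cc1` differs from compound 1 by cyclohexyl in place of methyl on an oxygen next to a carbonyl group. For the measured compounds named here, only one measured step touches the same place: because a number 12.2 percentage points higher from compound 1 to compound 2 (beyond the scatter) also enlarged the group on the oxygen next to the carbonyl group, a modest rise beyond the scatter is expected in this assay, about a number 10.6 percentage points higher from compound 1 to compound 3 (beyond the scatter). For compound 3 the estimate in this assay is 20%, likely between 8% and 40%.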

Compound 3, percent of the compound remaining: 14.6%
Compound 3: the middle estimate sits 5.4 percentage points above what was measured; the range from low to high includes it.
By their numbers in this assay, from the lowest: compounds 1, 3 and 2 (each within the scatter of the next, the first and the last beyond it).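

In this assay cyclohexyl on the oxygen next to the carbonyl group cannot be told apart from either methyl or butyl, with a number 5.2 percentage points higher from compound 1 to compound 3 (within the scatter) and a number 7 percentage points lower from compound 2 to compound 3 (within the scatter). A ring on this oxygen therefore does not repeat the clear gap between the methyl and butyl compounds, although compound 3 carries more carbon than either. Nothing measured here explains this result. As far as these compounds go, it remains open how a longer chain on this oxygen would read, and whether an amide or a carboxylic acid in place of this group would leave more of the compound.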